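The compounds below may be only part of what the source reports. "The series", "measured", "known", "first", "only" and "open" are said of these compounds alone.

Compound 3 `COc1cc(/C=C/C(=O)/C=C/c2cccc3ccccc23)ccc1OCc1cn(CCCOc2cc(=O)oc3ccccc23)nn1` stands second highest of the three numbers in a functional assay on HCT-116 cells (Homo sapiens) for inhibition, read by sulforhodamine B assay, with a stated time of 48 h, tested at 50 uM; on this read-out higher numbers stand for more inhibition of growth at the one concentration tested and lower numbers for less inhibition of growth: compound 2 `COc1cc(/C=C/C(=O)/C=C/c2cc(OC)c(OC)c(OC)c2)ccc1OCc1cn(CCCOc2cc(=O)oc3ccccc23)nn1` gives 76%, compound 3 gives 66%, and compound 1 `COc1cc(/C=C/C(=O)/C=C/c2ccccc2)ccc1OCc1cn(CCCOc2cc(=O)oc3ccccc23)nn1` gives 45%. The nearest step lies within the scatter, a number 10 percentage points lower from compound 2 to compound 3 (within the scatter), whereas a number 21 percentage points higher from compound 1 to compound 3 (beyond the scatter) and a number 31 percentage points higher from compound 1 to compound 2 (beyond the scatter) are both beyond it. Compound 4 `COc1cc(/C=C/C(=O)/C=C/c2ccco2)ccc1OCc1cn(CCCOc2cc(=O)oc3ccccc23)nn1` differs from compound 3 by furan-2-yl in place of naphthalen-1-yl on a double-bonded chain carbon bound to a double-bonded chain carbon. Going by the values given here, no measured step replaces naphthalen-1-yl with a five-membered aromatic ring; the only guide is that phenyl in compound 1 gave the lowest number of the set, which suggests that moving away from naphthalen-1-yl costs inhibition. The step in this assay is therefore expected to run downward, estimated as a number 18 percentage points lower from compound 3 to compound 4 (beyond the scatter). For compound 4 the expected value is 48%, with a range from 28% to 68%.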

Compound 4, percent growth inhibition at one concentration: 51%
For compound 4 the middle estimate is 3 percentage points below the measured one; the range from low to high includes it.
By their numbers in this assay, from the lowest: compounds 1 and 4 (each within the scatter of the next); then compounds 3 and 2 (each within the scatter of the next).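

In this assay, the place on a double-bonded chain carbon bound to a double-bonded chain carbon also accepts a five-membered aromatic ring, yet furan-2-yl does not hold the level of naphthalen-1-yl, with a number 15 percentage points lower from compound 3 to compound 4 (beyond the scatter). Against 3,4,5-trimethoxyphenyl the change gives a number 25 percentage points lower from compound 2 to compound 4 (beyond the scatter), whereas against phenyl it gives a number 6 percentage points higher from compound 1 to compound 4 (within the scatter), so furan-2-yl and phenyl cannot be separated here. No evidence at hand accounts for these differences.

Open, from the compounds shown here alone, is whether a pyridin-3-yl ring or a dimethylamino group on the phenyl ring would match compound 2 .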